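Benzyl Replaces Phenyl on the Shared Core

A few compounds are considered here, and "the series" means these few. Any claim that something is new, unique, unknown or untested is made for them only; others in the source may bear on it.

Of the compounds shown here, three with a shared core have been tested in an ADME assay on THP-1 cells (Homo sapiens) for cytotoxicity, read by MTT assay; a lower number here means that less compound is tolerated, a higher number that more compound is tolerated. Compound 1 `Cc1ccc(-c2nnc(-c3sc(-c4cccnc4)nc3C)o2)cc1` carries 4-methylphenyl; in this assay compound 1 gives only the limit > 100 ug/mL. Compound 2 `COc1ccccc1-c1nnc(-c2sc(-c3cccnc3)nc2C)o1` carries 2-methoxyphenyl in place of 4-methylphenyl; in this assay compound 2 gives only the limit > 100 ug/mL. Compound 3 `Cc1nc(-c2cccnc2)sc1-c1nnc(-c2ccccc2)o1` carries hydrogen in place of methyl; in this assay compound 3 likewise gives only the limit > 100 ug/mL. All three values sit at the limit of > 100 ug/mL in this assay, at which 3 of the 3 values shown sit. The steps a step that the two limits leave unreadable from compound 1 to compound 2, a step that the two limits leave unreadable from compound 1 to compound 3 and a step that the two limits leave unreadable from compound 2 to compound 3 are thus unreadable in size, and compound 3 stands at a limit, not at a number.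

Compound 4 `Cc1nc(-c2cccnc2)sc1-c1nnc(Cc2ccccc2)o1` has not yet been measured; it differs from compound 3 by benzyl in place of phenyl on an aromatic carbon. For the measured compounds named here, none of the measured steps bears directly on this change, and none of them can be read in size, so no direction can be drawn from them. Compound 4 is expected to stay near that limit, with an estimated step of a number no higher from compound 3 to compound 4 (the limit leaves the size open). Compound 4 is estimated at 100 ug/mL, between 50 ug/mL and 200 ug/mL.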

Compound 4, half-maximal cytotoxic concentration: > 100 ug/mL
Compound 4: no number, only a limit; the forecaster's own chance of this, stated with the estimate: 70%; the middle value sits exactly at the limit.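

In this assay compound 4 gives only the limit > 100 ug/mL. For the compounds shown here, no step from compound 1, compound 2 or compound 3 to compound 4 can be read in size: the limit of > 100 ug/mL in this assay, at which 4 of the 4 values shown sit. The compounds shown leave open where the half-maximal cytotoxic concentration of any of them lies, and whether benzyl in place of phenyl changes it.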